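The source may report more compounds than this note shows. Statements on the series, on what has been measured and on what is new or still open speak of the compounds shown alone.

Measured in a functional assay on L1210 cells (Mus musculus) for cytotoxicity, read by cell counting, with a stated time of 2 days; a higher number here means a weaker inhibitor, a lower number a stronger inhibitor:

Compound 1, `C=C(Br)C(=O)Nc1cccc(/C=C2\SC(=O)N(Cc3ccc(C)cc3)C2=O)c1`: 600 nM
Compound 3, `C=C(Br)C(=O)Nc1ccc(/C=C2\SC(=O)N(Cc3ccccc3)C2=O)cc1`: 1100 nM
Compound 2, `Nc1ccc(/C=C2\SC(=O)N(Cc3ccc(Cl)cc3)C2=O)cc1`: 37000 nM

Among these three numbers, compound 1 has the lowest. Its nearest neighbour is compound 3; the gap between the two lies within the usual scatter of this assay, so the two cannot be told apart on these numbers alone. Compound 2 stands far apart: its number is much higher than that of compound 1, a gap well beyond the scatter, and it also differs from compound 1 in more than one place, so no single change can be read out of that pair.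

Compound 4, `C=C(Br)C(=O)Nc1cccc(/C=C2\SC(=O)N(Cc3ccc(F)cc3)C2=O)c1`, has not yet been measured. It differs from compound 1 in one place: fluoro in place of methyl on an aromatic carbon. The methyl that leaves and the fluoro that enters are each a single heavy atom, carry no donor or acceptor and no charge, and sit on the same aromatic carbon, para to a large group. Going by the values given here, no measured pair among the three compounds shows this change, so its size is not known from the data. The change is small in what is counted. The step is expected to stay within the scatter, with no clear direction. Compound 4 is therefore estimated at 600 nM, in a range from 300 nM to 1500 nM, which corresponds to an expected step of no change at the digits printed from compound 1 to compound 4 (within the scatter).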

Compound 4, half-maximal inhibitory concentration: 680 nM
The estimate for compound 4 lay 1.1-fold (0.05 log units) below the measured number; the range from low to high includes it.
By their numbers in this assay, from the lowest: compounds 1, 4 and 3 (each within the scatter of the next); then compound 2.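

In this assay, going by these compounds alone, fluoro in place of methyl on this aromatic carbon gives a 1.1-fold higher number from compound 1 to compound 4 (0.05 log units; within the scatter) and this is the first step that changes one place only. It shows that at this spot, para to a large group, one single-atom group can stand in for the other without a change that can be told from the scatter, so compound 1 and compound 4 cannot be separated on these numbers. Nothing available explains this result or says how either group acts here.

This one step leaves open how groups of other kinds would read at this carbon, such as a methoxy, a carboxylic acid, an amine or a longer chain. It also leaves open what the group on the other aromatic ring contributes, as no pair shown changes that group alone.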